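This account rests on a few compounds, and the source may have more. Where it says the series, first, only, none or still open, it means among the compounds named here.

For the measured compounds named here, in a functional assay on CNE2Z cells (Homo sapiens) for inhibition, read by MTT assay, with a stated time of 72 h (on this read-out higher numbers stand for weaker inhibition and lower numbers for stronger inhibition), compound 2 (`C=CCc1ccc(OCc2ccc(Cl)cc2Cl)c(-c2ccc(O)c(CC=C)c2)c1`) gives 24200 nM as the only exact number so far. Compound 1 (`C=CCc1ccc(OCc2ccc(Cl)cc2Cl)c(-c2ccc(OCc3ccc(Cl)cc3Cl)c(CC=C)c2)c1`) stands at > 50000 nM as a limit of the assay and not a number. Compound 3 (`C=CCc1ccc(OCc2c(Cl)cccc2Cl)c(-c2ccc(O)c(CC=C)c2)c1`) has the same atoms as compound 2, joined differently: 2,6-dichlorophenyl in place of 2,4-dichlorophenyl on a saturated chain carbon bound to an oxygen on an aromatic ring is the whole change. Going by the values given here, the one measured step of an at least 2.0-fold lower number from compound 1 to compound 2 (0.31 log units; beyond the scatter) puts hydrogen in place of 2,4-dichlorobenzyl and so offers only a loose guide, since it does not test moving a chlorine. No shift beyond the scatter is therefore expected in this assay for this change. The estimated step of a 1.2-fold lower number from compound 2 to compound 3 (0.08 log units; within the scatter) stays small. Compound 3 is expected at 20000 nM (estimated range 8000 nM to 50000 nM) in this assay.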

Compound 3, half-maximal inhibitory concentration: 19900 nM
Estimate against measurement, compound 3: 1.0-fold (0.00 log units) above; measured number inside the range.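

In this assay, moving one chlorine on the benzyl group gives a 1.2-fold lower number from compound 2 to compound 3 (0.08 log units; within the scatter), so 2,4-dichlorophenyl and 2,6-dichlorophenyl read alike at this place. Unlike the earlier step, which replaced the whole 2,4-dichlorobenzyl group with hydrogen, this change keeps the group and alters only its chlorine pattern. Nothing measured here explains why the two patterns read alike.

From the compounds shown here alone, whether an unsubstituted phenyl, or a phenyl carrying an amine or a carboxylic acid, would also read alike on this carbon remains open. So does the effect of a longer chain between that ring and the oxygen.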